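The source may report more compounds than this note shows. Statements on the series, on what has been measured and on what is new or still open speak of the compounds shown alone.

Three compounds share one core and differ in the groups hung on it. Compound 1 `CC(C)(C)C(=O)N1Cc2c(NC(=O)c3cccnc3)n[nH]c2C1(C)C` gives 690 nM in a functional assay on A2780 cells (Homo sapiens) for antiproliferative activity, read by fluorescence, with a stated time of 72 h; on this read-out lower numbers stand for stronger inhibition and higher numbers for weaker inhibition. Compound 3 `CC(C)(C)C(=O)N1Cc2c(NC(=O)C3CCNCC3)n[nH]c2C1(C)C` gives 650 nM, and the change a 1.1-fold lower number from compound 1 to compound 3 (0.03 log units; within the scatter) shows that swapping the group on that carbonyl carbon left the number essentially where it was. Compound 2 `CN1CCC(C(=O)N2Cc3c(NC(=O)c4cccs4)n[nH]c3C2(C)C)CC1` gives 30 nM, the lowest of the three numbers, standing well beyond the scatter from both compound 1 and compound 3.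

Compound 4 `CN1CCC(C(=O)N2Cc3c(NC(=O)NCc4ccccc4)n[nH]c3C2(C)C)CC1` is not yet measured. It differs from compound 2 in one place: benzylamino in place of thiophen-2-yl on a carbonyl carbon.

Among the measured compounds shown here, only the step from compound 1 to compound 3 touches the same carbonyl carbon, and it stayed within the scatter. For the measured compounds named here, no measured pair covers the present swap itself, and compound 2 differs from the other two in more than one place, so the source of its low number is not settled. The expected outcome is therefore a somewhat higher number, with wide uncertainty, for compound 4, estimated at 120 nM (range 30 nM to 500 nM), a step of a 4.0-fold higher number from compound 2 to compound 4 (0.60 log units; beyond the scatter).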

Compound 4, half-maximal inhibitory concentration: 2680 nM
The estimate for compound 4 lay 22-fold (1.35 log units) below the measured number; measured number outside the range, above it.
By their numbers in this assay, from the lowest: compound 2; then compounds 3 and 1 (each within the scatter of the next); then compound 4.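

In this assay, benzylamino in place of thiophen-2-yl on this carbonyl carbon gives an 89-fold higher number from compound 2 to compound 4 (1.95 log units; beyond the scatter) and so marks a large change at this position. Among the compounds shown here, the only earlier swap on such a carbon, a 1.1-fold lower number from compound 1 to compound 3 (0.03 log units; within the scatter), stayed within the scatter, so it gave no sign that this position could respond so strongly. No supporting measurement is available to explain the size of this step.

The compounds shown do not separate the part played by the nitrogen of benzylamino from that of its benzyl portion. A benzyl group joined directly to the carbonyl carbon, or a phenylamino group in the same place, could help tell these apart, and a plain phenyl group would test how much depends on thiophen-2-yl itself.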